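A Morpholine Amide Swap in a Cystic Fibrosis Corrector Series

The source may report more compounds than this note shows. Statements on the series, on what has been measured and on what is new or still open speak of the compounds shown alone.

Three compounds were measured in an assay on cells with Cystic fibrosis transmembrane conductance regulator variant F508del (Homo sapiens) as the target, read by fluorescence, with stated times of 24 h and 30 min; on this read-out lower numbers stand for an effect already at smaller amounts and higher numbers for an effect only at larger amounts of compound. Compound 1 `COc1ccccc1C(=O)NCCCNc1nc2cc(C)cc(C)c2cc1C#N` gives 100000 nM in this assay, and compound 3 `CCN(C(C)=O)C1CCN(c2nc(-c3ccccn3)nc3c2CN(Cc2ccc(Cl)cc2)CC3)C1` gives 100000 nM. Compound 2 `COc1ccc(Cl)cc1Cc1cc(-c2sc(NC(=O)C(C)(C)C)nc2C)nn1C(=O)NCCO` gives 3020 nM, the lowest of the three numbers, and its gap to each of the other two lies beyond the usual scatter. Compound 4 `COc1ccc(Cl)cc1Cc1cc(-c2sc(NC(=O)C(C)(C)C)nc2C)nn1C(=O)N1CCOCC1` differs from compound 2 in one place: morpholin-4-yl in place of (2-hydroxyethyl)amino on a carbonyl carbon. Going by the values given here, no pair of measured compounds differs in only one place, so no measured step guides this change directly. Compound 4 is expected to land close to compound 2, with a step of a 1.3-fold higher number from compound 2 to compound 4 (0.12 log units; within the scatter) that is expected to stay within the scatter or run slightly toward a higher number. Compound 4 is therefore estimated at 4000 nM, within a range from 1500 nM to 12000 nM.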

Compound 4, half-maximal effective concentration: 1000 nM
The estimate for compound 4 lay 4.0-fold (0.60 log units) above the measured number; measured number below the stated range.
By their numbers in this assay, from the lowest: compound 4; then compound 2; then compounds 1 and 3 (each within the scatter of the next).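

In this assay, replacing (2-hydroxyethyl)amino with morpholin-4-yl on this carbonyl carbon gives a 3.0-fold lower number from compound 2 to compound 4 (0.48 log units; beyond the scatter), so the position accepts a six-membered non-aromatic ring in place of the open chain. The number also falls with 0 hydrogen-bond donors in the entering group, against 2 in the group that leaves, so those donors are not needed for an effect at this level. Nothing measured here accounts for the step.

As far as these compounds go, it remains open whether piperidin-1-yl, piperazin-1-yl or dimethylamino on the same carbonyl carbon would move the number further, and so whether the morpholine oxygen contributes at all.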